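One Chlorine Shift on a Second Core, One Expected Value

The compounds below may be only part of what the source reports. "The series", "measured", "known", "first", "only" and "open" are said of these compounds alone.

Three compounds have so far been measured in an assay on microsomes from brain for inhibition of Fatty-acid amide hydrolase 1 (Rattus norvegicus), read by fluorescence and HPLC, with a stated time of 60 min; a higher number here means a weaker inhibitor, a lower number a stronger inhibitor:

compound 1, `CCCCCCCCc1ccc(OCC(=O)Cn2nnc(-c3cccc(Cl)c3)n2)cc1`, gives 24 nM
compound 2, `CCCCCCCCc1ccc(OCC(=O)Cn2nnc(-c3ccccc3Cl)n2)cc1`, gives 32 nM
compound 3, `CCCCCCCCc1ccc(OCC(=O)Cn2nnnc2-c2cccc(Cl)c2)cc1`, gives 360 nM

Compound 1 and compound 2 share one core and differ in one group only: 2-chlorophenyl in place of 3-chlorophenyl on an aromatic carbon. That change produced a 1.3-fold higher number from compound 1 to compound 2 (0.12 log units; within the scatter). Compound 3 carries the same 3-chlorophenyl group on a different core; the difference between the two cores is not broken down here. In this assay compound 3 gives the highest number of the three, beyond the scatter from both compound 1 and compound 2.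

Compound 4, `CCCCCCCCc1ccc(OCC(=O)Cn2nnnc2-c2ccccc2Cl)cc1`, is not yet measured. It arises from compound 3 by the same kind of change that led from compound 1 to compound 2: 2-chlorophenyl in place of 3-chlorophenyl on an aromatic carbon. The surroundings are not identical: in compound 1 the group sits two ring bonds from the ring atom that bears a large group, whereas in compound 3 it sits next to the ring atom that bears a large group. A step of about a 1.2-fold higher number from compound 3 to compound 4 (0.07 log units; within the scatter) is expected, because the earlier step of a 1.3-fold higher number from compound 1 to compound 2 (0.12 log units; within the scatter) stayed within the scatter. Compound 4 is therefore estimated at 420 nM, with a likely range from 150 nM to 1200 nM.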

Compound 4, half-maximal inhibitory concentration: 4600 nM
For compound 4 the middle estimate is 11-fold (1.04 log units) below the measured one; measured number outside the range, above it.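

Putting 2-chlorophenyl in place of 3-chlorophenyl on the second core produced a 13-fold higher number from compound 3 to compound 4 (1.11 log units; beyond the scatter), a large step in this assay. The size of this change therefore did not carry over from one core to the other, and the two steps differ by more than repeated measurements would explain: the same change on two cores in this assay, a 1.3-fold higher number (0.12 log units; within the scatter) from compound 1 to compound 2 and a 13-fold higher number (1.11 log units; beyond the scatter) from compound 3 to compound 4, 9.6-fold (0.98 log units) apart, beyond the scatter of two such steps. This shows that, for these two pairs, the core affects how much the change matters, but it does not show which difference between the cores is responsible, and one pair on each core cannot establish a rule for the wider series.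

The compounds shown leave open whether a fluorine or a methyl group in place of the chlorine on the phenyl ring would reveal the same gap between the two cores. They also leave open whether that gap would remain if a shorter chain replaced the octyl chain.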